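A few compounds are considered here, and "the series" means these few. Any claim that something is new, unique, unknown or untested is made for them only; others in the source may bear on it.

Measured compounds:
compound 1 `NNC(=O)c1c(N)sc2c1CCCCCC2` gives 48% in a functional assay on CHO cells for agonist activity at adenosine receptor A1 (Homo sapiens), read by ERK phosphorylation, tested at 3 uM; on this read-out lower numbers stand for a weaker effect and higher numbers for a stronger effect at the one concentration tested;
compound 2 `Nc1sc2c(c1C(=O)NNc1ccccc1)CCCCC2` gives 44% in this assay.

Compound 1 stands highest of the two numbers recorded in this assay, but its nearest neighbour, compound 2, lies only slightly lower and within the scatter, so the two are not separated on this read-out. Within the data shown here, no step between measured compounds differing in a single place is available; compound 2 shares the phenyl on the amine nitrogen with the unmeasured compound but differs from compound 1 in its core as well, so its value shows only what that pairing of features gives.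

The step to compound 3 `Nc1sc2c(c1C(=O)NNc1ccccc1)CCCCCC2` is the change (phenyl in place of hydrogen on an amine nitrogen), which leaves the rest of compound 1 untouched. Among the measured compounds shown here, with no single-place step recorded, the size of this step in this assay is uncertain; since compound 2, carrying the same phenyl on the amine nitrogen, gives 44%, a step of no more than the scatter, in either direction, is expected. Compound 3 is therefore estimated at 45%, in a range from 25% to 65%, the expected step being a number 3 percentage points lower from compound 1 to compound 3 (within the scatter).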

Compound 3, a percentage reported as activity, at one concentration (the size of the read-out at that concentration, not a potency): 47%
Compound 3: the middle estimate sits 2 percentage points below what was measured; measured number inside the range.
By their numbers in this assay, from the lowest: compounds 2, 3 and 1 (each within the scatter of the next).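

In this assay the change from hydrogen to phenyl on an amine nitrogen whose other neighbour is an amide-type nitrogen now has a reading in one place, a number 1 percentage points lower from compound 1 to compound 3 (within the scatter) and so amino and anilino are not separated on this read-out. Among these compounds, this is the first direct sign that this position carries a six-membered aromatic ring of carbon only, with its 6 heavy atoms, without a difference that can be told from the scatter, something the earlier pair could not show since compound 1 and compound 2 differ in more than one place. Nothing at hand bears on the reason for this result.

The compounds shown leave open whether a methyl, a benzyl or a phenyl bearing a chlorine or a methoxy group on the same nitrogen would also stay within the scatter of compound 1, and whether any group there gives a separable change. They also leave open whether compound 1 and compound 3 would differ in the strength of their effect at any other concentration, as the read-out reports the size of the effect at one concentration only.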